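The source may report more compounds than this note shows. Statements on the series, on what has been measured and on what is new or still open speak of the compounds shown alone.

Of the compounds shown here, two have been measured in a functional assay on CHO cells for antagonist activity at Orexin/Hypocretin receptor type 1 (Homo sapiens), read by FLIPR and calcium flux; a higher number here means a weaker inhibitor, a lower number a stronger inhibitor. Compound 1, with the structure `CN[C@@H]1C[C@@H](c2c(OC)cccc2OC)N(Cc2ccc(OC(F)(F)F)cc2)C1=O`, gives 2400 nM in this assay. Compound 2, with the structure `COc1cccc(OC)c1[C@@H]1C[C@H](Cl)C(=O)N1Cc1ccc(OC(F)(F)F)cc1`, gives 65 nM in this assay. Of the two numbers, compound 2 has the lower one, and its nearest neighbour is compound 1, whose number lies well beyond the scatter of repeated measurements above it.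

Compound 3, with the structure `CN[C@H]1C[C@@H](c2c(OC)cccc2OC)N(Cc2ccc(OC(F)(F)F)cc2)C1=O`, has not yet been measured. It differs from compound 2 in one place: methylamino in place of chloro on a saturated ring carbon of the shared core. For the measured compounds named here, no step between measured compounds covers this particular change, so its size can only be estimated. The expectation is that compound 3 will give a weaker inhibition than compound 2, with a step of a 9.2-fold higher number from compound 2 to compound 3 (0.97 log units; beyond the scatter) in this assay, which would lie beyond the scatter. On that basis, compound 3 is estimated to give 600 nM in this assay, with a plausible range from 100 nM to 3000 nM.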

Compound 3, half-maximal inhibitory concentration: 5780 nM
Compound 3: middle estimate off by 9.6-fold (0.98 log units), on the low side; measured number above the stated range.
By their numbers in this assay, from the lowest: compound 2; then compound 1; then compound 3.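

In this assay, for the compounds shown here, the saturated ring carbon two ring bonds from the ring nitrogen proves highly sensitive to the group it carries: methylamino in place of chloro brings an 89-fold higher number from compound 2 to compound 3 (1.95 log units; beyond the scatter), a large loss of inhibition and the first direct reading of this change. The configuration at this carbon also matters, though the step is modest: the stereocentre drawn R in compound 1 and S in compound 3 gives a 2.4-fold higher number from compound 1 to compound 3 (0.38 log units; beyond the scatter). This modest step can be assigned to the drawn configuration alone, because nothing else separates the two methylamino compounds: the fact that compounds 1 and 3 differ only in the configuration as drawn

The compounds shown leave open whether the large step reflects something particular to methylamino or to chloro, since a fluoro, a hydroxyl, a dimethylamino group or a plain hydrogen at this carbon could separate those two readings. The configuration step is also read only with methylamino, so whether the chloro series responds in the same direction and to a similar extent remains an open question.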